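From Pyridin-4-yl to Pyrimidin-5-yl in Compound 1

This account rests on a few compounds, and the source may have more. Where it says the series, first, only, none or still open, it means among the compounds named here.

Among the compounds with values here, in a functional assay on CWR22R cells (Homo sapiens) for antiproliferative activity, read by CCK-8 assay, with a stated time of 6 days (on this read-out higher numbers stand for weaker inhibition and lower numbers for stronger inhibition), compound 1 (`CCN(c1ccc(C#N)c(Cl)c1)c1cc(-c2ccncc2)ccc1C`) gives 1030 nM, the only number available so far. A second structure, compound 2 (`Cc1noc(C)c1-c1cccc(Oc2ccc(C#N)c(C(F)(F)F)c2)c1`), offers no comparison, since the entry for compound 2 reads "not determined" (no result reported). Compound 1 therefore cannot yet be ranked against anything.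

Compound 3 (`CCN(c1ccc(C#N)c(Cl)c1)c1cc(-c2cncnc2)ccc1C`) keeps the core of compound 1 but carries pyrimidin-5-yl in place of pyridin-4-yl on an aromatic carbon. Within the data shown here, no measured step shows what this exchange does in this assay, so the expectation starts from compound 1 at 1030 nM. A six-membered aromatic ring stays at the same place, so only a small shift towards weaker inhibition is expected, possibly no larger than the usual scatter. The expected change is a 1.5-fold higher number from compound 1 to compound 3 (0.16 log units; within the scatter). For compound 3 the estimated value is 1500 nM, with an expected range of 500 nM to 4500 nM.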

Compound 3, half-maximal inhibitory concentration: > 30000 nM
Compound 3 ended at the assay's limit; the forecaster's own chance of this, stated with the estimate: 10%; at least 20-fold (1.30 log units) between middle value and limit.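

At this position, on an aromatic carbon para to a methyl group, exchanging one six-membered aromatic ring for another of the same heavy-atom count is far from a neutral change: in this assay pyrimidin-5-yl in place of pyridin-4-yl gives an at least 29-fold higher number from compound 1 to compound 3 (1.46 log units; beyond the scatter). On these data alone, the entry for compound 3, > 30000 nM, is a limit of the assay and not a number, so the full size of this step stays unknown: the limit of > 30000 nM in this assay, at which 1 of the 3 values shown sits. The activity of compound 1 thus proves sensitive to the make-up of this ring, which compound 1 alone could not show.

As far as these compounds go, whether a pyridin-3-yl ring, a plain phenyl ring or an amine at the same place would keep the activity of compound 1 remains open. The values also do not say why the step is so large.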